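This account rests on a few compounds, and the source may have more. Where it says the series, first, only, none or still open, it means among the compounds named here.

Series notes. Compound 3 `CCC(c1ccc(O)c(OC)c1)c1ccccc1O` gives 8530 nM in a functional assay, read by spectrophotometry, with a stated time of 30 min; on this read-out higher numbers stand for weaker inhibition and lower numbers for stronger inhibition. In this assay compound 1 `CCC(c1ccc(O)c(OC)c1)c1cccc(O)c1O` gives 8430 nM, and compound 2 `CCOc1cccc(C(CC)c2ccc(O)c(OC)c2)c1O` gives 7190 nM. The step of a 1.0-fold higher number from compound 1 to compound 3 (0.01 log units; within the scatter) and the step of a 1.2-fold higher number from compound 2 to compound 3 (0.07 log units; within the scatter) are both within the scatter, and so is the step of a 1.2-fold lower number from compound 1 to compound 2 (0.07 log units; within the scatter), so the measurement does not separate the three numbers and compound 3 cannot be set apart from the other two on what has been measured.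

Compound 4 `CCC(c1ccc(O)c(OC)c1)c1cccc(C(C)C)c1O` differs from compound 3 by isopropyl in place of hydrogen on an aromatic carbon, on an aromatic carbon of a six-membered aromatic ring of carbon only, ortho to a hydroxy group and meta to a large group. The measured steps that touch this carbon are a 1.0-fold higher number from compound 1 to compound 3 (0.01 log units; within the scatter) and a 1.2-fold higher number from compound 2 to compound 3 (0.07 log units; within the scatter): whether hydroxy, ethoxy or hydrogen occupies it, the number in this assay stays within the scatter. Isopropyl has not been tried at this carbon, but nothing in the series points to a change beyond the scatter, so no step beyond the scatter is expected in this assay. Compound 4 is therefore estimated to give 8500 nM, with an expected range from 4000 nM to 18000 nM. The expected step is a 1.0-fold lower number from compound 3 to compound 4 (0.00 log units; within the scatter), a change of no consequence within the scatter.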

Compound 4, half-maximal inhibitory concentration: 7000 nM
The estimate for compound 4 lay 1.2-fold (0.08 log units) above the measured number; low and high end bracket the measured number.
By their numbers in this assay, from the lowest: compounds 4, 2, 1 and 3 (each within the scatter of the next).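

In this assay the step of a 1.2-fold lower number from compound 3 to compound 4 (0.09 log units; within the scatter) stays within the scatter, as do the step of a 1.0-fold lower number from compound 2 to compound 4 (0.01 log units; within the scatter) and the step of a 1.2-fold lower number from compound 1 to compound 4 (0.08 log units; within the scatter) in this series of comparisons. Until now the aromatic carbon ortho to a hydroxy group and meta to a large group had carried only hydrogen, hydroxy or ethoxy; isopropyl, with its 3 heavy atoms (3 carbon) and no hydrogen-bond donors or acceptors, extends the set of groups at this carbon that cannot be told apart on this read-out, so the four compounds remain a single group by their numbers. No supporting information is available to explain why the number stays within the scatter across these groups.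

Open, from the compounds shown here alone, is whether a carboxylic acid, an amine or a longer chain such as n-hexyl at this carbon would give a step beyond the scatter, or would also leave the number where these four compounds stand. Also open, going by these compounds, is whether any change elsewhere on the shared core, including the hydroxy group on the same ring, would move the number beyond the scatter.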